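Trimethylphenyl ether on the uracil-linked aminopyrimidine series

The source may hold more compounds than are shown below. What is called first, only, known or untested is meant among the compounds shown, and "the series" means these compounds.

Measured compounds:
compound 1 `Cc1cc(C)c(Oc2nc(Cl)ncc2NCCn2ccc(=O)[nH]c2=O)c(C)c1` – 2890 nM
compound 2 `Cc1cc(C)cc(Oc2ccnc(NCCn3ccc(=O)[nH]c3=O)n2)c1` – 74800 nM

In an ADME assay on MT4 cells (Homo sapiens) for cytotoxicity, read by MTT assay, with a stated time of 5 days (a higher number here means that more compound is tolerated, a lower number that less compound is tolerated), compound 2 gives the highest of the two numbers; compound 1 gives 2890 nM, a gap beyond the scatter. Compound 3 `Cc1cc(C)c(Oc2ccnc(NCCn3ccc(=O)[nH]c3=O)n2)c(C)c1` has not been measured. It differs from compound 2 by 2,4,6-trimethylphenyl in place of 3,5-dimethylphenyl on an oxygen on an aromatic ring. Among the compounds with values here, with no step between measured compounds to guide this change, the account expects compound 3 to be tolerated less than compound 2, and the step of a 3.7-fold lower number from compound 2 to compound 3 (0.57 log units; beyond the scatter) is estimated to lie beyond the scatter. Compound 3 is estimated at 20000 nM in this assay, within 5000 nM to 80000 nM.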

Compound 3, half-maximal cytotoxic concentration: 272000 nM
Beside the measured number, compound 3's estimate is 14-fold (1.13 log units) below it; measured number outside the range, above it.
By their numbers in this assay, from the lowest: compound 1; then compound 2; then compound 3.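

In this assay, 2,4,6-trimethylphenyl in place of 3,5-dimethylphenyl on an oxygen on an aromatic ring gives a 3.6-fold higher number from compound 2 to compound 3 (0.56 log units; beyond the scatter), so more compound is tolerated with the larger group of 9 heavy atoms. This single change on an otherwise shared core is enough to move the number beyond the scatter. No measurement shown gives a reason for this step.

As far as these compounds go, it remains open how an unsubstituted phenyl or a cyclohexyl group would behave at this position. From the compounds shown here alone, it also remains open whether a chlorine on the core, taken alone, would change the number.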